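Sulfonyl aryl group and thromboxane-type inhibition

This account rests on a few compounds, and the source may have more. Where it says the series, first, only, none or still open, it means among the compounds named here.

Measured compounds:
compound 1 `Cc1ccc(S(=O)(=O)N[C@H]2C3CC[C@H](C3)[C@@H]2C/C=C\CCCC(=O)O)cc1` — 500 nM
compound 2 `Cc1ccccc1S(=O)(=O)N[C@H]1C2CC[C@H](C2)[C@@H]1C/C=C\CCCC(=O)O` — 6200 nM
compound 3 `O=C(O)CCC/C=C\C[C@H]1[C@@H]2CCC(C2)[C@@H]1NS(=O)(=O)c1ccccc1` — 1000 nM; 7400 nM; 600 nM (3 entries)

Three compounds share a bicyclic core bearing a heptenoic acid chain and an arylsulfonamide, and differ only in the aryl group on the sulfonyl sulfur. In a functional assay (plasma) for inhibition, with Oryctolagus cuniculus as the target (a higher number here means a weaker inhibitor, a lower number a stronger inhibitor), compound 1 gives 500 nM, while compound 2 gives 6200 nM, the highest of the two single numbers. The step of a 12-fold higher number from compound 1 to compound 2 (1.09 log units; beyond the scatter) is large and exceeds the scatter. Compound 3 gives 1000 nM; 7400 nM; 600 nM (3 entries); the spread of these entries, (the several entries of compound 3 in this assay, 1000 nM; 7400 nM; 600 nM (3 entries)), shows how far repeated measurements of one compound can lie apart, so the phenyl compound cannot be placed firmly against the other two.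

Compound 4 `O=C(O)CCC/C=C\C[C@H]1[C@@H]2CCC(C2)[C@@H]1NS(=O)(=O)c1ccc(Cl)cc1` is unmeasured. It differs from compound 2 as follows: 4-chlorophenyl in place of 2-methylphenyl on a sulfonyl sulfur. Compound 4 thus carries a 4-chlorophenyl, resembling the 4-methylphenyl of compound 1 rather than the 2-methylphenyl of compound 2. Among the compounds with values here, the one measured step that bears on this change is a 12-fold higher number from compound 1 to compound 2 (1.09 log units; beyond the scatter), and since compound 4 reverses that aryl pattern, a step of similar size in the opposite direction is expected. Compound 4 is therefore estimated at 450 nM, within 120 nM to 1800 nM, which means the expected step of a 14-fold lower number from compound 2 to compound 4 (1.14 log units; beyond the scatter).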

Compound 4, half-maximal inhibitory concentration: 300 nM
For compound 4 the middle estimate is 1.5-fold (0.18 log units) above the measured one, within the range that was stated.
By their numbers in this assay, from the lowest: compounds 4 and 1 (each within the scatter of the next); then compound 2.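

In this assay the exchange of 2-methylphenyl for 4-chlorophenyl on the sulfonyl sulfur gives a 21-fold lower number from compound 2 to compound 4 (1.32 log units; beyond the scatter) and so places compound 2 apart from a second compound, not from compound 1 alone. Chloro in place of methyl on an aromatic carbon gives a 1.7-fold lower number from compound 1 to compound 4 (0.22 log units; within the scatter) and leaves compound 1 and compound 4 indistinguishable in this measurement. Among these three compounds, the large steps therefore separate the 2-methylphenyl from both the 4-methylphenyl and the 4-chlorophenyl, whereas methyl and chloro on the two latter aryl groups cannot be told apart.

The compounds shown leave open whether the high number of compound 2 goes with the methyl group or with its place on the ring, which a 2-chlorophenyl or a 3-methylphenyl on the same sulfur would address. Compound 3, with its unsubstituted phenyl, neither supports nor goes against this pattern, because its entries lie too far apart to give a firm reference: the several entries of compound 3 in this assay, 1000 nM; 7400 nM; 600 nM (3 entries)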